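The source may hold more compounds than are shown below. What is called first, only, known or untested is meant among the compounds shown, and "the series" means these compounds.

Measured compounds:
compound 1, `Nc1scc(CN2CCN(c3ccccc3C(F)(F)F)CC2)c1C(=O)c1ccc(Cl)cc1`, gives -39%;
compound 2, `Nc1scc(CN2CCC(c3ccc(Cl)cc3)CC2)c1C(=O)c1ccc(Cl)cc1`, gives -24%;
compound 3, `Nc1scc(CN2CCN(c3c(F)cccc3F)CC2)c1C(=O)c1cccc(C(F)(F)F)c1`, gives 1.3%.

In a functional assay on CHO cells with adenosine receptor A1 (Homo sapiens) as the target, read by cAMP accumulation and immunoassay, with a stated time of 6 min, tested at 1 uM (a higher number here means a weaker effect of the compound at the concentration tested, a lower number a stronger effect), compound 1 holds the lowest of the three numbers; compound 2 lies higher, beyond the scatter, and compound 3 lies higher still, also beyond the scatter. Among the compounds with values here, no two measured compounds differ in one place only, so no measured single step is available. Compound 4, `Nc1scc(CN2CCN(c3cccc(F)c3)CC2)c1C(=O)c1ccc(Cl)cc1`, differs from compound 1 in one place: 3-fluorophenyl in place of 2-(trifluoromethyl)phenyl on an amine nitrogen in a ring. Within the data shown here, with no measured step to rest on, a modest rise in this assay is expected, perhaps not far beyond the scatter. The expected step is a number 17 percentage points higher from compound 1 to compound 4 (beyond the scatter). For compound 4 an activity of -22% is expected, within the range -48% to 8%.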

Compound 4, a percentage reported as activity, at one concentration (the size of the read-out at that concentration, not a potency): -86%
The estimate for compound 4 lay 64 percentage points above the measured number; the whole stated range lies above it.
By their numbers in this assay, from the lowest: compound 4; then compound 1; then compound 2; then compound 3.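

On the amine nitrogen in the ring, the aryl group is not a neutral choice: in this assay, 3-fluorophenyl in place of 2-(trifluoromethyl)phenyl gives a number 47 percentage points lower from compound 1 to compound 4 (beyond the scatter), a large move towards a stronger effect and the only single-place step shown in the series. The compounds shown do not separate the loss of trifluoromethyl from the arrival of fluorine, and a plain phenyl, 2-fluorophenyl or 3-(trifluoromethyl)phenyl on that nitrogen would be needed to divide the step. No measured information bears on the reason for its size.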